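Trimming the Alkoxy Chain: Compound 2 to Compound 4

This account rests on a few compounds, and the source may have more. Where it says the series, first, only, none or still open, it means among the compounds named here.

Of the compounds shown here, three sharing one core have been tested in a functional assay on RAW264.7 cells (Mus musculus) for inhibition, read by immunoassay, with a stated time of 12 h, tested at 30 uM; on this read-out lower numbers stand for less inhibition and higher numbers for more inhibition at the one concentration tested (going by the name of the read-out). Compound 1 `CC(C)c1ccc(COc2ccccc2C2CC(=O)c3ccccc3O2)cc1` gives 91.5% in this assay. Compound 2 `CC(C)COc1ccccc1C1CC(=O)c2ccccc2O1` gives 30.4% in this assay, and compound 3 `COc1ccccc1C1CC(=O)c2ccccc2O1` gives 37.3% in this assay. Compound 2 thus stands far apart from compound 1, with a number 61.1 percentage points lower from compound 1 to compound 2 (beyond the scatter), and close to compound 3, with a number 6.9 percentage points higher from compound 2 to compound 3 (within the scatter), a gap within the scatter. Compound 4 `CCOc1ccccc1C1CC(=O)c2ccccc2O1` has not yet been measured. It differs from compound 2 in one place: methyl in place of isopropyl on a saturated chain carbon bound to an oxygen on an aromatic ring. Going by the values given here, the steps that bear on this are those on a saturated chain carbon bound to an oxygen on an aromatic ring. Between compound 2 and compound 3 the change from isopropyl to hydrogen stayed within the scatter, whereas the large drops, a number 61.1 percentage points lower from compound 1 to compound 2 (beyond the scatter) and a number 54.2 percentage points lower from compound 1 to compound 3 (beyond the scatter), both came only with the loss of 4-isopropylphenyl. Replacing isopropyl with methyl at that carbon is therefore expected to produce a number 2.6 percentage points higher from compound 2 to compound 4 (within the scatter), within the scatter. For compound 4 the estimate in this assay is 33%, ranging from 20% to 48%.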

Compound 4, a percentage reported as inhibition, at one concentration (the size of the read-out at that concentration, not a potency): 29.6%
The estimate for compound 4 lay 3.4 percentage points above the measured number; measured number inside the range.
By their numbers in this assay, from the lowest: compounds 4, 2 and 3 (each within the scatter of the next); then compound 1.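

Methyl at this carbon now fills the gap between hydrogen and isopropyl: it gives a number 0.8 percentage points lower from compound 2 to compound 4 (within the scatter) and, set against hydrogen, a number 7.7 percentage points lower from compound 3 to compound 4 (within the scatter) so these three groups cannot be told apart here. Only 4-isopropylphenyl stands apart, with a number 61.9 percentage points lower from compound 1 to compound 4 (beyond the scatter) and this large step now holds against three small groups rather than two. Nothing measured here explains why these groups behave alike or why 4-isopropylphenyl differs.

The compounds shown leave open whether the high number needs the whole 4-isopropylphenyl group or only a ring at this carbon, which a plain phenyl would test. They also leave open where between isopropyl and 4-isopropylphenyl the number begins to climb, and whether a longer chain such as n-hexyl would raise it.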